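What a Phenoxy Group Might Do to Compound 1

The compounds below may be only part of what the source reports. "The series", "measured", "known", "first", "only" and "open" are said of these compounds alone.

Among the compounds with values here, only two compounds with this shared core have been measured so far. In a functional assay on HeLa cells (Homo sapiens) for cytotoxicity, read by MTT assay, with a stated time of 48 h (a lower number here means a stronger inhibitor, a higher number a weaker inhibitor), compound 1 (`CC1(C)CCC[C@]2(C)[C@@H](CC[C@@](C)(O)/C=C/c3ccccc3)[C@](C)(O)CC[C@@H]12`) gives 3320 nM and compound 2 (`Cc1cccc(/C=C/[C@](C)(O)CC[C@@H]2[C@@]3(C)CCCC(C)(C)[C@@H]3CC[C@@]2(C)O)c1C`) gives 3700 nM as its measured value. Compound 1 therefore has a single neighbour on the scale, and the two cannot be told apart.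

Compound 3 (`CC1(C)CCC[C@]2(C)[C@@H](CC[C@@](C)(O)/C=C/c3ccc(Oc4ccccc4)cc3)[C@](C)(O)CC[C@@H]12`) differs from compound 1 by one change (phenoxy in place of hydrogen on an aromatic carbon), phenoxy in place of hydrogen on an aromatic carbon. Within the data shown here, the only measured step that touches the same aromatic ring is small (a 1.1-fold higher number from compound 1 to compound 2 (0.05 log units; within the scatter)), with 2,3-dimethylphenyl in place of phenyl. Among the measured compounds shown here, a single step involving a different group is thin evidence, and no measured compound carries phenoxy, so the data point in no direction. The change expected in this assay is therefore none beyond the scatter, with the estimated step being a 1.1-fold lower number from compound 1 to compound 3 (0.04 log units; within the scatter) for now. For compound 3 the estimated value is 3000 nM as a working figure. The expected range for compound 3 runs from 1200 nM to 8000 nM and is kept wide.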

Compound 3, half-maximal inhibitory concentration: 3480 nM
Compound 3: middle estimate off by 1.2-fold (0.06 log units), on the low side; the range from low to high includes it.
By their numbers in this assay, from the lowest: compounds 1, 3 and 2 (each within the scatter of the next).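

In this assay, phenoxy in place of hydrogen on an aromatic carbon, para to a large group, gives a step that cannot be told apart from no difference at all (a 1.0-fold higher number from compound 1 to compound 3 (0.02 log units; within the scatter)). The earlier pair spoke only to 2,3-dimethylphenyl in place of phenyl, whereas this change adds 7 heavy atoms and a second six-membered aromatic ring, so this position can carry a much larger group while compound 3 stays within the scatter of compound 1. All three compounds now sit close together on the scale, and nothing measured here offers an explanation for that closeness.

The compounds shown carry only hydrocarbon and ether groups on this ring, so it remains open whether an amine or a carboxylic acid at the same aromatic carbon would shift the number beyond the scatter. On these data alone, it also remains open whether a change elsewhere on the shared core, such as a longer chain between the double bond and the core, would matter more than anything placed on this ring.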